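Urea versus thiourea analogues in HeLa cytotoxicity

The source may hold more compounds than are shown below. What is called first, only, known or untested is meant among the compounds shown, and "the series" means these compounds.

Values given here come from a functional assay on HeLa cells (Homo sapiens) for cytotoxicity, read by MTT assay, with a stated time of 48 h; on this read-out higher numbers stand for weaker inhibition and lower numbers for stronger inhibition.

Measured compounds:
compound 1, `COc1cc(/C=C/C(=O)C2=C(/C=C/c3ccc(O)c(OC)c3)NC(=O)NC2c2ccc(N(C)C)cc2)ccc1O`: 25000 nM
compound 2, `COc1cc(/C=C/C(=O)C2=C(/C=C/c3ccc(O)c(OC)c3)NC(=O)NC2c2c(Cl)cccc2Cl)ccc1O`: 25000 nM
compound 3, `COc1cc(/C=C/C(=O)C2=C(/C=C/c3ccc(O)c(OC)c3)NC(=S)NC2c2ccc(N(C)C)cc2)ccc1O`: 12500 nM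

The change from compound 1 to compound 2 is 2,6-dichlorophenyl in place of 4-(dimethylamino)phenyl on a saturated ring carbon, and the step it made in this assay is no change at the digits printed from compound 1 to compound 2 (within the scatter). Compound 3 stands apart from compound 1 in its core; the difference between the two cores is not broken down here. In this assay compound 3 gives 12500 nM, which lies within the scatter of both compound 1 and compound 2, so no order among the three is claimed.

Compound 4, `COc1cc(/C=C/C(=O)C2=C(/C=C/c3ccc(O)c(OC)c3)NC(=S)NC2c2c(Cl)cccc2Cl)ccc1O`, has not yet been measured. It differs from compound 3 by 2,6-dichlorophenyl in place of 4-(dimethylamino)phenyl on a saturated ring carbon, the same change, at the same place, as that from compound 1 to compound 2. Because that earlier step was no change at the digits printed from compound 1 to compound 2 (within the scatter), the step from compound 3 to compound 4 is expected to be no change at the digits printed from compound 3 to compound 4 (within the scatter), again within the scatter. Compound 4 is therefore estimated at 12500 nM in this assay, with a likely range from 5000 nM to 30000 nM.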

Compound 4, half-maximal inhibitory concentration: 100000 nM
For compound 4 the middle estimate is 8.0-fold (0.90 log units) below the measured one; measured number outside the range, above it.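

Working notes on the series: in this assay, 2,6-dichlorophenyl in place of 4-(dimethylamino)phenyl on the saturated ring carbon gives an 8.0-fold higher number from compound 3 to compound 4 (0.90 log units; beyond the scatter), so on the core of compound 3 this change carries a cost beyond the scatter. The same change does not carry over at a constant size between the two cores: the same change on two cores in this assay, no change at the digits printed (within the scatter) from compound 1 to compound 2 and an 8.0-fold higher number (0.90 log units; beyond the scatter) from compound 3 to compound 4, 8.0-fold (0.90 log units) apart, beyond the scatter of two such steps

This shows that the result of this change on the core of compound 1 is a poor guide to its result on the core of compound 3, but it rests on a single matched pair of steps and does not show why the two steps differ or whether other replacements depend on the core in the same way.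

The compounds shown leave open how a plain phenyl, a carboxylic acid or an aliphatic amine at this ring carbon would behave on either core. They also leave open whether any such group would separate the two cores as 2,6-dichlorophenyl does.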